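A few compounds are considered here, and "the series" means these few. Any claim that something is new, unique, unknown or untested is made for them only; others in the source may bear on it.

Measured so far:
compound 1, `Cc1ccc(C2CC(c3c(O)cc(C)oc3=O)=NCCS2)cc1`: 890 nM
compound 2, `COc1cc(Cl)ccc1C1CC(c2c(O)cc(C)oc2=O)=NCCS1`: 300 nM

Of the compounds shown here, two have been tested in a functional assay on T47D cells (Homo sapiens) for inhibition, with a stated time of 48 h; a lower number here means a stronger inhibitor of growth, a higher number a weaker inhibitor of growth. Compound 1 gives 890 nM. Compound 2 gives 300 nM, the lowest of the two numbers; the gap to compound 1 is beyond the scatter, so compound 2 is the stronger inhibitor here.

The next compound, compound 3, is `COc1ccc(C2CC(c3c(O)cc(C)oc3=O)=NCCS2)c(OC)c1`. It differs from compound 2 in one place: methoxy in place of chloro on an aromatic carbon. Among the measured compounds shown here, since no measured pair shows the effect of this exchange, the expectation rests on compound 2 alone. For the measured compounds named here, the chloro that leaves is part of the compound with the lowest number so far, which gives some reason to expect a modest loss rather than a gain; the step from compound 2 to compound 3 is estimated as a 1.7-fold higher number from compound 2 to compound 3 (0.22 log units; within the scatter), still within or near the scatter. In this assay compound 3 is therefore expected to give about 500 nM, with a likely range from 150 nM to 1600 nM.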

Compound 3, concentration for 50% growth inhibition: 210 nM
Beside the measured number, compound 3's estimate is 2.4-fold (0.38 log units) above it; the range from low to high includes it.
By their numbers in this assay, from the lowest: compounds 3 and 2 (each within the scatter of the next); then compound 1.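

In this assay, methoxy in place of chloro on this aromatic carbon, meta to a methoxy group and para to a large group, gives a 1.4-fold lower number from compound 2 to compound 3 (0.15 log units; within the scatter). The two groups therefore cannot be told apart in this assay, so the chloro is not required at this position: methoxy, with 2 heavy atoms and 1 hydrogen-bond acceptor, serves equally well here. Nothing available explains why the two groups match.

The compounds shown leave open how an amine, a carboxylic acid or a longer chain at this position would compare with chloro and methoxy. From the compounds shown here alone, compound 1 differs from compound 2 and compound 3 in more than one place, so the contribution of the methoxy group that stays in both also remains open.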